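Swapping 1-phenylethyl for cyclobutyl on an amide nitrogen

The source may hold more compounds than are shown below. What is called first, only, known or untested is meant among the compounds shown, and "the series" means these compounds.

Of the compounds shown here, three sharing one core have been tested so far in a functional assay on HT-29 cells (Homo sapiens) for inhibition, read by MTT assay, with a stated time of 120 h; a lower number here means a stronger inhibitor, a higher number a weaker inhibitor (a measure of how much compound is needed to hold back the cells). Compound 1 `O=C(/C=C/c1ccc(NC(=O)Nc2ccc(Cl)c(C(F)(F)F)c2)cc1)NC1CCC1` gives 4430 nM and compound 2 `CC(NC(=O)C#Cc1ccc(NC(=O)Nc2ccc(Cl)c(C(F)(F)F)c2)cc1)c1ccccc1` gives 4920 nM in this test. Compound 3 `CC(NC(=O)CCc1ccc(NC(=O)Nc2ccc(Cl)c(C(F)(F)F)c2)cc1)c1ccccc1` gives 26500 nM as the highest number of the three, which makes it the weakest inhibitor, with a gap to both others that lies beyond the scatter.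

Compound 4 `O=C(CCc1ccc(NC(=O)Nc2ccc(Cl)c(C(F)(F)F)c2)cc1)NC1CCC1` differs from compound 3 at one place, with cyclobutyl in place of 1-phenylethyl on an amide-type nitrogen. Going by the values given here, no measured pair shows this change alone, so the evidence is indirect. Compound 1 carries cyclobutyl there and gives 4430 nM on a different chain, while compound 2 carries 1-phenylethyl there and gives 4920 nM on another chain. These two values lie within the scatter of each other, so no large shift is expected. A small expected move toward a lower number, a 1.7-fold lower number from compound 3 to compound 4 (0.22 log units; within the scatter) (probably within the scatter), seems most likely. The estimate for compound 4 is 16000 nM (expected range 6000 nM to 40000 nM).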

Compound 4, half-maximal inhibitory concentration: 21300 nM
Compound 4: middle estimate off by 1.3-fold (0.12 log units), on the low side, within the range that was stated.
By their numbers in this assay, from the lowest: compounds 1 and 2 (each within the scatter of the next); then compounds 4 and 3 (each within the scatter of the next).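

In this assay, going by these compounds alone, swapping 1-phenylethyl for cyclobutyl on the amide-type nitrogen gives a 1.2-fold lower number from compound 3 to compound 4 (0.09 log units; within the scatter), the first direct reading of this change, so the two groups cannot be told apart on this chain even though only one carries a six-membered aromatic ring. The chain itself does register, with 2-(cyclobutylcarbamoyl)ethyl in place of 2-(cyclobutylcarbamoyl)ethenyl on an aromatic carbon giving a 4.8-fold higher number from compound 1 to compound 4 (0.68 log units; beyond the scatter), a modest step beyond the scatter. No measurement shown here offers an explanation for either step.

Still open, on these data alone, is whether cyclobutyl and 1-phenylethyl also match when the chain is the ethenyl or ethynyl one. As far as these compounds go, how a much smaller group such as methyl, or a group carrying an amine such as 2-aminoethyl, would read on the same nitrogen also remains unknown.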